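Benzothiazole for Fluoroquinoline in a 5-Lipoxygenase Inhibitor Series

A few compounds are considered here, and "the series" means these few. Any claim that something is new, unique, unknown or untested is made for them only; others in the source may bear on it.

Measured so far:
compound 1 `O=C(O)/C(CCc1ccccc1)=N/OC(c1ccc(OCc2ccc3ccccc3n2)cc1)C1CCCCC1` — 20 nM
compound 2 `C/C(=N\OC(c1ccc(OCc2ccc3cc(F)ccc3n2)cc1)C1CCCCC1)C(=O)O` — 20 nM

Both compounds were tested in a functional assay for inhibition of Polyunsaturated fatty acid 5-lipoxygenase (Homo sapiens); on this read-out lower numbers stand for stronger inhibition and higher numbers for weaker inhibition. Compound 1 gives 20 nM in this assay. Compound 2, which carries a shorter acid chain and a fluorine on the quinoline, gives 20 nM in this assay; the two values stand level at the digits shown, and the difference lies within the scatter, so no order between compound 1 and compound 2 can be read from them.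

Compound 3 `C/C(=N\OC(c1ccc(OCc2nc3ccccc3s2)cc1)C1CCCCC1)C(=O)O` has not yet been measured. It differs from compound 2 in one place: 1,3-benzothiazol-2-yl in place of 6-fluoroquinolin-2-yl on a saturated chain carbon bound to an oxygen on an aromatic ring. Among the measured compounds shown here, no measured pair in the set shows a change of this kind, so the expectation rests on the two values alone and on the fact that the rest of the molecule is unchanged. The author expects a modest step toward weaker inhibition, a 3.0-fold higher number from compound 2 to compound 3 (0.48 log units; beyond the scatter), though a result within the scatter of compound 2 is also plausible. The estimate for compound 3 in this assay is 60 nM, with a range from 15 nM to 300 nM.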

Compound 3, half-maximal inhibitory concentration: 60 nM
Compound 3: middle estimate and measured number agree at the digits printed; measured number inside the range.
By their numbers in this assay, from the lowest: compounds 1 and 2 (each within the scatter of the next); then compound 3.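

Among the compounds shown here, in this position, on a saturated chain carbon bound to an oxygen on an aromatic ring, the first one-place comparison in the set shows that the two bicyclic groups are not interchangeable: putting 1,3-benzothiazol-2-yl in place of 6-fluoroquinolin-2-yl gives a 3.0-fold higher number from compound 2 to compound 3 (0.48 log units; beyond the scatter) in this assay. The step is modest, and the change does not abolish inhibition: compound 3 still gives 60 nM with a five-membered aromatic ring with 2 hetero atoms and a sulfur in the group, and with 9 heavy atoms, fewer than in the group that left. No measurement of any property of these groups is available to explain the step.

The change alters ring size, hetero atoms and the fluorine all at once, so the compounds shown cannot say which of these carries the step; a quinolin-2-yl without the fluorine, or a 1,3-benzothiazol-2-yl carrying a fluorine, on the same acid chain would separate them. As far as these compounds go, it also remains open whether the step would hold with the longer acid chain of compound 1 in place of the shorter one.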